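The source may hold more compounds than are shown below. What is called first, only, known or untested is meant among the compounds shown, and "the series" means these compounds.

Measured compounds:
- compound 1, `CCN(CC)CCN1CCN(C(=O)COCCN(C)S(=O)(=O)c2c(C)cc(OC)cc2C)CC1`, gives 10 nM in an assay on HEK293 cells for displacement of a labelled ligand from B1 bradykinin receptor (Homo sapiens), read by scintillation counting; a higher number here means a weaker inhibitor, a lower number a stronger inhibitor
- compound 2, `COc1ccc(S(=O)(=O)N(C)CCOCC(=O)N(C)Cc2ccc(C3=NCCN3)cc2)c(C)c1`, gives 5.5 nM in this assay

Compound 2 has the lowest of the two numbers recorded in this assay, but its nearest neighbour, compound 1, sits within the scatter of repeated measurement, so no order between the two can be claimed. Both compounds share the sulfonamide-ether-amide chain and differ in the groups at either end.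

Compound 3, `Cc1c(Cl)ccc(S(=O)(=O)N(C)CCOCC(=O)N(C)Cc2ccc(C3=NCCN3)cc2)c1Cl`, keeps the whole of compound 2 except for one change: 2,4-dichloro-3-methylphenyl in place of 4-methoxy-2-methylphenyl on a sulfonyl sulfur. Among the measured compounds shown here, no pair of measured compounds shows this change, so there is no measured step from which to read its size. The two measured compounds differ in several places at once and still give numbers within the scatter of each other, which suggests that the chain tolerates variation without large shifts in this assay.

For compound 3 the step from compound 2 is therefore expected to be small, in either direction, and not beyond the scatter, as a 1.4-fold lower number from compound 2 to compound 3 (0.14 log units; within the scatter). Compound 3 is estimated to give 4 nM in this assay, with a range of 1.2 nM to 14 nM.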

Compound 3, inhibition constant: 2.1 nM
Beside the measured number, compound 3's estimate is 1.9-fold (0.28 log units) above it; low and high end bracket the measured number.
By their numbers in this assay, from the lowest: compound 3; then compounds 2 and 1 (each within the scatter of the next).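

Compounds 1 and 2 differ in several places at once, so they could not show what the aryl group on the sulfonyl sulfur contributes on its own. Compound 2 and compound 3 isolate that group, and in this assay the replacement of 4-methoxy-2-methylphenyl by 2,4-dichloro-3-methylphenyl gives a 2.6-fold lower number from compound 2 to compound 3 (0.42 log units; beyond the scatter), showing that a change at this one place can move the number modestly past the scatter while the rest of the molecule stays fixed. The two groups have the same heavy-atom count, but the entering group has two chlorine atoms and no oxygen, and no available evidence connects any part of this exchange with the step.

Among the compounds shown here, the single step cannot separate the loss of the methoxy group from the arrival of either chlorine atom, and it leaves open how a phenyl ring carrying only one chlorine, a trifluoromethyl group or a nitrile would compare. As far as these compounds go, it is also open whether 2,4-dichloro-3-methylphenyl would give a similar step when paired with the diethylaminoethyl-bearing end of compound 1.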